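The source may hold more compounds than are shown below. What is called first, only, known or untested is meant among the compounds shown, and "the series" means these compounds.

Compound 1 `COc1ccc(/C=C/C(=O)c2ccccc2-c2ccc(F)cc2)cc1OC` gives 81 nM
Compound 2 `COc1ccc(/C=C/C(=O)c2ccccc2-c2cccc(F)c2)cc1` gives 73 nM

In a functional assay on CNE-2 cells (Homo sapiens) for antiproliferative activity, read by sulforhodamine B assay, with a stated time of 48 h (on this read-out lower numbers stand for stronger inhibition and higher numbers for weaker inhibition), compound 2 stands at 73 nM and compound 1 at 81 nM and these two numbers lie within the usual scatter of each other. The two compounds differ in more than one place, so no single structural change can be read from them.

Compound 3 `COc1ccc(/C=C/C(=O)c2ccccc2-c2cccc(F)c2)cc1OC` is built from compound 2 by one change, methoxy in place of hydrogen on an aromatic carbon, ortho to a methoxy group and meta to a large group methoxy in place of hydrogen on an aromatic carbon in full. For the measured compounds named here, the only guides are the close values of compound 1 and compound 2, so no large shift in this assay is expected in either direction. The expected size of a 1.0-fold lower number from compound 2 to compound 3 (0.02 log units; within the scatter) stays within the scatter. Compound 3 is estimated at 70 nM (expected range 28 nM to 180 nM).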

Compound 3, half-maximal inhibitory concentration: 650 nM
Beside the measured number, compound 3's estimate is 9.3-fold (0.97 log units) below it; measured number outside the range, above it.
By their numbers in this assay, from the lowest: compounds 2 and 1 (each within the scatter of the next); then compound 3.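

In this assay, methoxy in place of hydrogen on the aromatic carbon ortho to a methoxy group and meta to a large group is far from a neutral change, giving an 8.9-fold higher number from compound 2 to compound 3 (0.95 log units; beyond the scatter) in this series. With that methoxy present, the fluorine's placement also matters, since 3-fluorophenyl in place of 4-fluorophenyl gives an 8.0-fold higher number from compound 1 to compound 3 (0.90 log units; beyond the scatter) on the same read-out. Compound 3 therefore shares one feature with each earlier compound, yet each single difference separates it from them beyond the scatter, something the close values of compound 1 and compound 2 could not reveal on their own.

No available measurement explains these steps. Still open, on these data alone, is how a hydroxy group or an amine would read at this carbon, and whether the methoxy step keeps its size alongside 4-fluorophenyl.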